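Side-chain change on the aromatic nitrogen: compound 3

This account rests on a few compounds, and the source may have more. Where it says the series, first, only, none or still open, it means among the compounds named here.

Going by the values given here, compound 2 `CC[C@H](C1CC1)n1c(=O)c(C)nc2c(-c3ccc(Cl)cc3Cl)ccnc21` gives 8.2 nM in a functional assay for antagonist activity at corticotropin-releasing factor receptor 1 (Rattus norvegicus) (a higher number here means a weaker inhibitor, a lower number a stronger inhibitor), the lowest of the two numbers measured so far, while compound 1 `Cc1nc2c(-c3ccc(Cl)cc3Cl)ccnc2n(C(C)C(C)C)c1=O` gives 380 nM. Among the compounds with values here, the single measured step, a 46-fold lower number from compound 1 to compound 2 (1.67 log units; beyond the scatter), shows that the group on the aromatic nitrogen moves this read-out strongly. Compound 3 `CC[C@H](COC)n1c(=O)c(C)nc2c(-c3ccc(Cl)cc3Cl)ccnc21` differs from compound 2 at that same site: methoxymethyl in place of cyclopropyl on a saturated chain carbon bound to an aromatic nitrogen and a saturated chain carbon. Within the data shown here, no measured step exchanges a ring for a chain at this position; the step from compound 1 to compound 2 only shows that the site is sensitive and gives no direction for the present exchange. A step of a 3.0-fold higher number from compound 2 to compound 3 (0.48 log units; beyond the scatter) is therefore expected, most likely a modest rise in this assay with wide uncertainty. Compound 3 is estimated at 25 nM, with a range from 6 nM to 110 nM.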

Compound 3, half-maximal inhibitory concentration: 4 nM
Compound 3: middle estimate off by 6.3-fold (0.80 log units), on the high side, outside the stated range (below it).
By their numbers in this assay, from the lowest: compound 3; then compound 2; then compound 1.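

In this assay, the exchange gives a 2.1-fold lower number from compound 2 to compound 3 (0.31 log units; beyond the scatter), so the three-membered ring of the 1-cyclopropylpropyl group is not needed for a low number at this position; an open chain holding an oxygen serves at least as well. Against the branched all-carbon group of compound 1, the 1-(methoxymethyl)propyl group gives a 95-fold lower number from compound 1 to compound 3 (1.98 log units; beyond the scatter), the largest step in the series so far. Nothing at hand explains why this exchange lowers the number.

Still open, as far as these compounds go, is whether the oxygen or the loss of the ring drives the step; a propyl group in place of methoxymethyl would separate the two. Also open, from the compounds shown here alone, is how a hydroxymethyl or a dimethylaminomethyl group would read on that saturated chain carbon.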